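A few compounds are considered here, and "the series" means these few. Any claim that something is new, unique, unknown or untested is made for them only; others in the source may bear on it.

In a physicochemical assay for lipophilicity (a lower number here means a more polar compound, a higher number a more lipophilic compound), three compounds have been measured. Compound 1 `COc1cc(/C=C2\CCC/C(=C\c3cccc([N+](=O)[O-])c3)C2=O)cc(OC)c1OC` gives 5.06, compound 2 `CN(C)c1ccc(/C=C2\CCC/C(=C\c3ccc([N+](=O)[O-])cc3)C2=O)cc1` gives 5.08, and compound 3 `CN(C)c1ccc(/C=C2\CCC/C(=C\c3cccc([N+](=O)[O-])c3)C2=O)cc1` gives 5.06. Compound 2 differs from compound 3 by 4-nitrophenyl in place of 3-nitrophenyl on a double-bonded chain carbon bound to a double-bonded ring carbon, and the step is a number 0.02 log units higher from compound 3 to compound 2 (within the scatter). Compound 1 and compound 3 carry different cores; the difference between the two cores is not broken down here, and their values in this assay sit level with each other.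

Compound 4 `COc1cc(/C=C2\CCC/C(=C\c3ccc([N+](=O)[O-])cc3)C2=O)cc(OC)c1OC` awaits measurement. It differs from compound 1 by 4-nitrophenyl in place of 3-nitrophenyl on a double-bonded chain carbon bound to a double-bonded ring carbon, the same change that was made from compound 3 to compound 2, so the change occurs twice among these compounds. The step from compound 1 to compound 4 in this assay is estimated at a number 0.02 log units higher from compound 1 to compound 4 (within the scatter), beside the earlier step. That expectation rests on the step of a number 0.02 log units higher from compound 3 to compound 2 (within the scatter). Compound 4 is therefore expected to give 5.08, with a range from 4.8 to 5.35.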

Compound 4, partition coefficient: 5.08
The estimate for compound 4 equals the measured number at the digits printed, and the stated range covers the measured number.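

In this assay the step for 4-nitrophenyl in place of 3-nitrophenyl is a number 0.02 log units higher from compound 1 to compound 4 (within the scatter) and, on the other core, a number 0.02 log units higher from compound 3 to compound 2 (within the scatter), so the change carries from one core to the other with steps of the same printed size. Neither step can be told from the scatter, and two pairs do not show that the change would behave alike on any further core. Nothing measured here speaks to why the two steps agree.

The compounds shown leave open how an amine or a carboxylic acid in place of the nitro group would read in this assay. They also leave open whether the same swap holds on a core carrying a longer chain.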